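Series notes: one chloro removed from the aryl group of compound 2

The source may hold more compounds than are shown below. What is called first, only, known or untested is meant among the compounds shown, and "the series" means these compounds.

Measured compounds:
compound 1 `CC(C)c1ccc(Nc2ccc3c(OCCCN4CCN(C)CC4)cccc3n2)cc1` — 16100 nM in a functional assay on IGROV-1 cells (Homo sapiens) for inhibition, read by sulforhodamine B assay, with a stated time of 48 h; on this read-out lower numbers stand for stronger inhibition of growth and higher numbers for weaker inhibition of growth
compound 2 `CN1CCN(CCCOc2cccc3nc(Nc4cc(Cl)cc(Cl)c4)ccc23)CC1` — 1680 nM in this assay

For the measured compounds named here, on the two numbers in hand compound 2 stands at the lower one, and the only measured step is a 9.6-fold lower number from compound 1 to compound 2 (0.98 log units; beyond the scatter), a swap of the whole aryl group on the ring nitrogen. Compound 3 `CN1CCN(CCCOc2cccc3nc(Nc4cccc(Cl)c4)ccc23)CC1` differs from compound 2 by hydrogen in place of chloro on an aromatic carbon. Going by the values given here, no measured step removes a single chloro, so the step from compound 1 to compound 2 bears on it only indirectly: it shows that the aryl substitution pattern moves the number well beyond the scatter, with the 3,5-dichlorophenyl of compound 2 giving the lower value. Taking away one of its two chloro groups is expected to cost some of that, so for compound 3 a step of a 1.9-fold higher number from compound 2 to compound 3 (0.28 log units; within the scatter) in this assay is expected, a modest rise at most. Compound 3 is therefore estimated at 3200 nM, with a range of 1200 nM to 8500 nM.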

Compound 3, concentration for 50% growth inhibition: 2230 nM
Beside the measured number, compound 3's estimate is 1.4-fold (0.16 log units) above it; the measured number falls inside the stated range.
By their numbers in this assay, from the lowest: compounds 2 and 3 (each within the scatter of the next); then compound 1.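

In this assay the loss of one chloro gives a 1.3-fold higher number from compound 2 to compound 3 (0.12 log units; within the scatter), so at this aromatic carbon hydrogen and chloro cannot be told apart on this read-out. The earlier step changed the whole aryl group; this one shows that the 3-chlorophenyl group alone still keeps the number well away from that of the 4-isopropylphenyl group, with a 7.2-fold lower number from compound 1 to compound 3 (0.86 log units; beyond the scatter). Nothing available on these compounds accounts for either step.

Open, going by these compounds, is whether the remaining chloro matters at all, which a plain phenyl group would test, and whether a methoxy or trifluoromethyl group in its place would move the number beyond the scatter. Also open, on these data alone, is how these aryl groups behave with a longer chain to the methylpiperazine.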